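Compound 3 to Compound 4: Two Bromines Replace One Chlorine

This account rests on a few compounds, and the source may have more. Where it says the series, first, only, none or still open, it means among the compounds named here.

Among the three compounds measured in an assay on isolated protein for inhibition of phosphodiesterase 4A (Sus scrofa) (a higher number here means a weaker inhibitor, a lower number a stronger inhibitor), compound 3 `COc1ccc(C(=O)Nc2ccncc2Cl)cc1OC1CCCC1` stands lowest, at 16 nM. Its nearest neighbour is compound 1 `COc1ccc(C(=O)Nc2ccccc2Cl)cc1OC1CCCC1`, which in this assay gives 190 nM; the move a 12-fold lower number from compound 1 to compound 3 (1.07 log units; beyond the scatter) separates them. Compound 2 `COc1ccc(C(=O)Nc2nccs2)cc1OC1CCCC1` gives 6500 nM, and the steps of a 410-fold lower number from compound 2 to compound 3 (2.61 log units; beyond the scatter) and a 34-fold higher number from compound 1 to compound 2 (1.53 log units; beyond the scatter) place it furthest away.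

The next compound, compound 4 `COc1ccc(C(=O)Nc2c(Br)cncc2Br)cc1OC1CCCC1`, differs from compound 3 in one place: 3,5-dibromopyridin-4-yl in place of 3-chloropyridin-4-yl on an amide-type nitrogen. Among the measured compounds shown here, every measured step so far exchanges the whole aromatic ring on the amide-type nitrogen, and all three were large. For the measured compounds named here, none of them exchanges one halogen for another on a ring that is otherwise kept, and none adds a second halogen, so no measured step matches this change directly. The step of a 12-fold lower number from compound 1 to compound 3 (1.07 log units; beyond the scatter) shows that a halogenated pyridinyl on this nitrogen sits at the strong end of the series, and compound 4 keeps a halogenated pyridinyl. The expectation for this assay is therefore a step from compound 3 to compound 4 that stays near the scatter, written as a 1.6-fold higher number from compound 3 to compound 4 (0.19 log units; within the scatter). Compound 4 is estimated at 25 nM, within 8 nM to 80 nM.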

Compound 4, half-maximal inhibitory concentration: 7 nM
The estimate for compound 4 lay 3.6-fold (0.55 log units) above the measured number, outside the stated range (below it).
By their numbers in this assay, from the lowest: compound 4; then compound 3; then compound 1; then compound 2.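

In this assay, among the compounds shown here, the step of a 2.3-fold lower number from compound 3 to compound 4 (0.36 log units; beyond the scatter) is the first to keep the six-membered aromatic ring with its one hetero atom while changing only what that ring carries, and it shows that this position on the amide-type nitrogen still responds to such a change, by a modest amount beyond the scatter. With the steps of a 27-fold lower number from compound 1 to compound 4 (1.43 log units; beyond the scatter) and a 930-fold lower number from compound 2 to compound 4 (2.97 log units; beyond the scatter) also beyond the scatter, compound 4 is the strongest inhibitor of the four, so 3,5-dibromopyridin-4-yl is the best group on this nitrogen among those shown. Nothing available bears on why this change lowers the number.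

The change replaces the chlorine with bromine and adds a second halogen in one move, so the compounds shown cannot separate the effect of the halogen's identity from that of the halogen count; a ring carrying two chlorines, or a single bromine, would be needed to do so. They also leave open whether the halogens can give way to a non-halogen group such as methyl, methoxy or an amine.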